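This account rests on a few compounds, and the source may have more. Where it says the series, first, only, none or still open, it means among the compounds named here.

Measured so far in a functional assay on MCF7 cells (Homo sapiens) for inhibition, read by colorimetric assay and MTT assay, with a stated time of 72 h; a higher number here means a weaker inhibitor, a lower number a stronger inhibitor:

Compound 1, `COc1ccc2c(c1)-c1cnc(n1C)OCCCCCCCCO2`, gives 32000 nM.
Compound 2, `Cn1c2cnc1OCCCCCCCCOc1ccc(F)cc1-2`, gives 52000 nM.
Compound 3, `C=CCCCCOc1ccc(OC)cc1-c1cnc(OCCC=C)n1C`, gives 37000 nM.

Compound 1 and compound 2 share one core and differ in a single place: fluoro in place of methoxy on an aromatic carbon. In this assay this change gives a 1.6-fold higher number from compound 1 to compound 2 (0.21 log units; within the scatter), so the two values cannot be told apart.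

Compound 3 stands on a different core from compound 1; the difference between the two cores is not broken down here. Its value in this assay sits within the scatter of both compound 1 and compound 2, so none of the three can be set above or below another.

Compound 4, `C=CCCCCOc1ccc(F)cc1-c1cnc(OCCC=C)n1C`, has not yet been measured. It differs from compound 3 in one place: fluoro in place of methoxy on an aromatic carbon. Among the compounds with values here, this is the same kind of change as the one from compound 1 to compound 2, but the surroundings differ: in compound 1 the ring is part of a fused or bridged system of three rings, meta to a fused ring and para to a fused ring, while in compound 3 the carbon is meta to a large group and para to a (hex-5-en-1-yl)oxy group.

Given that the earlier instance gave a 1.6-fold higher number from compound 1 to compound 2 (0.21 log units; within the scatter), a step of about a 1.5-fold higher number from compound 3 to compound 4 (0.17 log units; within the scatter) is expected from compound 3 to compound 4 in this assay. Compound 4 is therefore estimated at 55000 nM, most likely between 25000 nM and 120000 nM.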

Compound 4, half-maximal inhibitory concentration: 43000 nM
For compound 4 the middle estimate is 1.3-fold (0.11 log units) above the measured one, within the range that was stated.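

In this assay, putting fluoro in place of methoxy on the aromatic carbon of the open-chain core gives a 1.2-fold higher number from compound 3 to compound 4 (0.07 log units; within the scatter), so this pair cannot be told apart. Set beside the same change on the core of compound 1, the two steps do not differ: the same change on two cores in this assay, a 1.6-fold higher number (0.21 log units; within the scatter) from compound 1 to compound 2 and a 1.2-fold higher number (0.07 log units; within the scatter) from compound 3 to compound 4, 1.4-fold (0.15 log units) apart, within the scatter of two such steps. Within the data shown here, this shows that the swap gave no readable change on either core and that nothing separates its outcome on one core from its outcome on the other, but it does not show that a real effect of the swap carries across, since neither step stands clear of the scatter and only two cores are represented.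

The compounds shown leave open whether an amine or a carboxylic acid on that aromatic carbon, or a shorter or longer chain in place of the (hex-5-en-1-yl)oxy group, would give a value that stands clear of the scatter. They also leave open how the same exchange of methoxy for fluoro would read on a third core.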